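Swapping the Benzyl Substituent: Toward a Trifluoromethylphenyl Analogue

The source may report more compounds than this note shows. Statements on the series, on what has been measured and on what is new or still open speak of the compounds shown alone.

Compound 1 `OC[C@H]1O[C@@H](n2cnc3c(NCc4cccc(F)c4)ncnc32)[C@H](O)[C@@H]1O`: 15300 nM
Compound 2 `OC[C@H]1O[C@@H](n2cnc3c(NCc4ccccc4Br)ncnc32)[C@H](O)[C@@H]1O`: > 166000 nM
Compound 3 `COc1cccc(CNc2ncnc3c2ncn3[C@@H]2O[C@H](CO)[C@@H](O)[C@H]2O)c1O`: 20200 nM

The three measured compounds share one core and differ only in the aryl group on a saturated chain carbon bound to a nitrogen on an aromatic ring. In a functional assay on MCF cells (Homo sapiens) for antiproliferative activity, with a stated time of 72 h (a higher number here means a weaker inhibitor, a lower number a stronger inhibitor), compound 1 gives 15300 nM. For compound 2 the assay reports no number but a limit, > 166000 nM. Compound 3 gives 20200 nM, the higher of the two numbers shown, with compound 1 nearest; that step, a 1.3-fold higher number from compound 1 to compound 3 (0.12 log units; within the scatter), lies within the scatter. By contrast an at least 10-fold higher number from compound 1 to compound 2 (1.03 log units; beyond the scatter), and in the return direction an at least 8.2-fold lower number from compound 2 to compound 3 (0.91 log units; beyond the scatter).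

Compound 4 `OC[C@H]1O[C@@H](n2cnc3c(NCc4ccc(C(F)(F)F)cc4)ncnc32)[C@H](O)[C@@H]1O` carries the change (4-(trifluoromethyl)phenyl in place of 2-hydroxy-3-methoxyphenyl on a saturated chain carbon bound to a nitrogen on an aromatic ring). Within the data shown here, no measured compound carries a 4-(trifluoromethyl)phenyl, so no step speaks to it directly. The step of a 1.3-fold higher number from compound 1 to compound 3 (0.12 log units; within the scatter) shows that exchanging one aryl group for another can leave the number unchanged, while an at least 10-fold higher number from compound 1 to compound 2 (1.03 log units; beyond the scatter) shows that a different exchange can move it far. With a fluorine-bearing aryl group in compound 1 giving 15300 nM, the expectation for compound 4 is a number near that of compound 3, with a step of a 1.0-fold lower number from compound 3 to compound 4 (0.00 log units; within the scatter) not beyond the scatter. Compound 4 is therefore estimated at 20000 nM, between 7000 nM and 70000 nM.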

Compound 4, half-maximal inhibitory concentration: > 166000 nM
Compound 4: no number, only a limit; the forecaster's own chance of this, stated with the estimate: 10%; middle value at least 8.3-fold (0.91 log units) away from the limit.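

In this assay compound 4 gives no number but a limit, > 166000 nM, so the 4-(trifluoromethyl)phenyl group stands with the 2-bromophenyl group of compound 2 rather than with the other two aryl groups. Among these compounds, the two readable steps (an at least 8.2-fold higher number from compound 3 to compound 4 (0.91 log units; beyond the scatter)) and (an at least 10-fold higher number from compound 1 to compound 4 (1.03 log units; beyond the scatter)) show that the large loss at this position is not confined to the one aryl group that earlier stood out, and that fluorine on the aryl group does not by itself keep a measurable number, since compound 1 and compound 4 both carry it. The step from compound 2 to compound 4 cannot be read, as both values are limits and the two compounds cannot be ordered: the limit of > 166000 nM in this assay, at which 2 of the 4 values shown sit.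

The compounds shown leave open whether the loss in compound 4 belongs to the trifluoromethyl group itself or to the whole 4-(trifluoromethyl)phenyl group. Going by these compounds, it also remains open whether an amine, a nitrile or a carboxylic acid in place of the trifluoromethyl group would return a number within the range of compound 1 and compound 3.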